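One Ethyl Added to a Weakly Cytotoxic Compound

A few compounds are considered here, and "the series" means these few. Any claim that something is new, unique, unknown or untested is made for them only; others in the source may bear on it.

compound 1 `CCCCCCCCCCn1cc(-c2nc3ccccc3cc2CCCC)nn1`: > 100 ug/mL
compound 2 `Cc1cc2ccccc2nc1-c1cn(-c2ccc(F)cc2)nn1`: > 100 ug/mL
compound 3 `CCc1cc2ccccc2nc1-c1cn(CCC(F)(F)C(F)(F)C(F)(F)C(F)(F)C(F)(F)C(F)(F)C(F)(F)C(F)(F)F)nn1`: 95.2 ug/mL

Going by the values given here, in a functional assay on COLO 205 cells (Homo sapiens) for cytotoxicity, read by MTT assay, with a stated time of 24 h (a lower number here means a stronger inhibitor, a higher number a weaker inhibitor), compound 3 gives 95.2 ug/mL, the only number among the three. The result for compound 1 is a limit of the assay, not a number. The result for compound 2 is likewise a limit. Compound 3 therefore stands alone as a measured value, and it sits just under (the limit of > 100 ug/mL in this assay, at which 2 of the 3 values shown sit), so even this one number describes a very weak inhibitor.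

Compound 4 `CCCCc1cc2ccccc2nc1-c1cn(CCC(F)(F)C(F)(F)C(F)(F)C(F)(F)C(F)(F)C(F)(F)C(F)(F)C(F)(F)F)nn1` differs from compound 3 by ethyl in place of hydrogen on a saturated chain carbon, two bonds along the chain from an aromatic carbon. Among the compounds with values here, no measured pair shows this change directly, so the size of the step is not known from the data. Compound 1 also carries butyl at the corresponding place and returns only a limit. Given how close compound 3 already lies to the limit, compound 4 is expected to move by no more than the scatter, the estimated step being a 1.1-fold higher number from compound 3 to compound 4 (0.02 log units; within the scatter), with a fair chance that only a limit is reported. Compound 4 is thus estimated at 100 ug/mL, within 50 ug/mL to 200 ug/mL.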

Compound 4, half-maximal inhibitory concentration: > 100 ug/mL
Compound 4 gave a limit, no number; the forecaster's own chance of this, stated with the estimate: 55%; the middle value lies on the limit itself.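

In this assay compound 4 gives > 100 ug/mL, which is a limit of the assay and not a number. Going by these compounds alone, this gives the first direct reading of ethyl in place of hydrogen on a saturated chain carbon, two bonds along the chain from an aromatic carbon, as an at least 1.0-fold higher number from compound 3 to compound 4 (0.02 log units; that floor lies within the scatter), so the change brings no sign of a stronger inhibitor at this position. Compound 4 joins compound 1 and compound 2 at the same limit: the limit of > 100 ug/mL in this assay, at which 3 of the 4 values shown sit.

The true size of the step cannot be read, as only its floor is known. On these data alone, whether an amine or a carboxylic acid on this saturated chain carbon would give a number clearly under the limit remains open.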